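The compounds below may be only part of what the source reports. "The series", "measured", "known", "first", "only" and "open" are said of these compounds alone.

Measured in a functional assay on HL-60 cells (Homo sapiens) for antiproliferative activity, read by MTT assay, with a stated time of 24 h; a lower number here means a stronger inhibitor, a higher number a weaker inhibitor:
- Compound 1 `CCCCc1oc2ccccc2c1C(=O)c1ccc(OCC(=O)Nc2ccccc2)cc1`: > 50000 nM, a limit and not a number
- Compound 2 `CCCCc1oc2ccccc2c1C(=O)c1ccc(OCC(=O)N[C@H](C)c2ccccc2)cc1`: > 50000 nM, a limit and not a number
- Compound 3 `CCCCc1oc2ccccc2c1C(=O)c1ccc(OCCCC(=O)N2CCCC2)cc1`: 29900 nM

For the measured compounds named here, compound 3 holds the only true number of the three. Beyond it there is only (the limit of > 50000 nM in this assay, at which 2 of the 3 values shown sit).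

Compound 4 `CCCCc1oc2ccccc2c1C(=O)c1ccc(OCCCC(=O)NCc2ccccc2)cc1` keeps the chain and the shared core of compound 3 and changes only the amide end: benzylamino in place of pyrrolidin-1-yl on a carbonyl carbon. In words, benzylamino stands in place of pyrrolidin-1-yl on a carbonyl carbon.

Going by the values given here, no measured step makes this exact change. The nearest are an at least 1.6-fold lower number from compound 1 to compound 3 (0.22 log units; that floor lies within the scatter) and an at least 1.6-fold lower number from compound 2 to compound 3 (0.22 log units; that floor lies within the scatter). Both also change the chain, and neither floor clears the scatter. The remaining step, a step that the two limits leave unreadable from compound 1 to compound 2, gives no size to work with.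

Compound 4 does share an aromatic ring on the amide side with compound 1 and compound 2, so a slight lean toward a higher number is expected, but no step beyond the scatter. The expected step is a 1.2-fold higher number from compound 3 to compound 4 (0.08 log units; within the scatter). A report of only a limit would be no surprise.

For compound 4 the estimated value is 36000 nM, with an expected range of 15000 nM to 80000 nM.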

Compound 4, half-maximal inhibitory concentration: 28900 nM
Beside the measured number, compound 4's estimate is 1.2-fold (0.10 log units) above it; the range from low to high includes it.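

In this assay, for the compounds shown here, the change on this carbonyl carbon, benzylamino in place of pyrrolidin-1-yl, is the first step with a true number at both ends, and it reads a 1.0-fold lower number from compound 3 to compound 4 (0.01 log units; within the scatter). A five-membered non-aromatic ring gives way here to a six-membered aromatic ring of carbon only and an amide hydrogen, yet the two values lie within the scatter of each other, so on this chain the assay does not separate the two amide ends. Compound 3 and compound 4 are the only ones with true numbers, and the other values shown remain limits and not numbers: the limit of > 50000 nM in this assay, at which 2 of the 4 values shown sit.

The compounds shown contain no pair that differs in the chain alone, so the part played by the chain cannot be separated from that of the amide end. As far as these compounds go, it remains open whether a different chain end, such as a morpholin-4-yl amide or a free carboxylic acid, or a longer chain carrying the same benzylamino end, would give a step beyond the scatter.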